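The source may report more compounds than this note shows. Statements on the series, on what has been measured and on what is new or still open speak of the compounds shown alone.

Measured compounds and their numbers in an assay for inhibition of very long chain fatty acid elongase 6 (Homo sapiens); on this read-out higher numbers stand for weaker inhibition and lower numbers for stronger inhibition:

- compound 1 `O=C1Nc2ccc(N3CCOC3=O)cc2C(CNC(=O)c2ccc(F)cc2)(C(F)(F)F)O1`: 67 nM
- compound 2 `CC(C)C1(COC(=O)Nc2ccc(F)cc2)OC(=O)Nc2ccc(Cl)cc21`: 5030 nM
- compound 3 `O=C1Nc2ccc(Cl)cc2C(CNC(=O)c2ccccc2F)(C(F)(F)F)O1`: 539 nM

Compound 3 stands second highest of the three. Its nearest neighbour is compound 1, whose number is lower by a margin beyond the scatter; compound 2 lies further away, with a higher number, again beyond the scatter. Compound 3 is therefore neither the strongest nor the weakest of the set on this assay.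

Compound 4 `Cc1cccc(C(=O)NCC2(C(F)(F)F)OC(=O)Nc3ccc(Cl)cc32)c1` is not yet measured. It differs from compound 3 in one place: 3-methylphenyl in place of 2-fluorophenyl on a carbonyl carbon. For the measured compounds named here, no measured pair isolates this change, so its size cannot be read from a step already known; compound 1 carries a differently substituted phenyl ring on the same carbonyl, but its core also differs, so its number alone does not settle the question.

The expectation for this assay is a step of a 1.2-fold higher number from compound 3 to compound 4 (0.08 log units; within the scatter) of small size, within or close to the scatter, with the direction uncertain. Compound 4 is estimated at 650 nM, with a range from 200 nM to 2200 nM.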

Compound 4, half-maximal inhibitory concentration: 437 nM
The estimate for compound 4 lay 1.5-fold (0.17 log units) above the measured number; low and high end bracket the measured number.
By their numbers in this assay, from the lowest: compound 1; then compounds 4 and 3 (each within the scatter of the next); then compound 2.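

In this assay, for the compounds shown here, the change from 2-fluorophenyl to 3-methylphenyl on a carbonyl carbon gives a 1.2-fold lower number from compound 3 to compound 4 (0.09 log units; within the scatter) as the first step that isolates a single place. With the shared core held fixed, the two substituted phenyl groups cannot be told apart on this read-out, so this exchange of equal heavy-atom count leaves the number within the scatter. No measurement is available that would explain the step.

The fluorine and the methyl group also stand at different ring positions. The groups 2-methylphenyl and 3-fluorophenyl would be needed to separate the identity of the group from its place. Going by these compounds, it also remains open whether an amine or a carboxylic acid on this phenyl ring, or a longer chain in place of the ring, would shift the number beyond the scatter.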